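2-Fluorobenzyl to 2-chlorobenzyl: one halogen exchanged

The source may hold more compounds than are shown below. What is called first, only, known or untested is meant among the compounds shown, and "the series" means these compounds.

In a functional assay on MCF7 cells (Homo sapiens) for cytotoxicity, read by MTT assay, with a stated time of 24 h (on this read-out higher numbers stand for weaker inhibition and lower numbers for stronger inhibition), compound 1 `COc1ccc(/C=C2\CN(C(=S)SCc3cn(Cc4ccccc4F)nn3)C/C(=C\c3ccc(OC)cc3)C2=O)cc1` gives 79400 nM and compound 2 `COc1ccc(/C=C2\CN(Cc3cn(Cc4cccc(Cl)c4)nn3)C/C(=C\c3ccc(OC)cc3)C2=O)cc1` gives 99000 nM, two values within the scatter of each other. Compound 3 `Cc1ccc(/C=C2\CN(C(=S)SCc3cn(Cc4ccccc4F)nn3)C/C(=C\c3ccc(C)cc3)C2=O)cc1` is recorded only as a limit of the assay, > 100000 nM. Compound 4 `COc1ccc(/C=C2\CN(C(=S)SCc3cn(Cc4ccccc4Cl)nn3)C/C(=C\c3ccc(OC)cc3)C2=O)cc1` differs from compound 1 by a single exchange, chloro in place of fluoro on an aromatic carbon, ortho to a large group (chloro in place of fluoro on an aromatic carbon). Among the measured compounds shown here, no measured pair of compounds differs in only one place, so the data give no direct size for such a step, and none beyond the scatter is expected in this assay. The estimated 1.0-fold higher number from compound 1 to compound 4 (0.00 log units; within the scatter) stays within that scatter. Compound 4 is expected at 80000 nM, with an estimated range of 40000 nM to 120000 nM.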

Compound 4, half-maximal inhibitory concentration: > 100000 nM
Compound 4: only a limit was reported; the forecaster's own chance of this, stated with the estimate: 30%; at least 1.2-fold (0.09 log units) between middle value and limit.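

In this assay, among the compounds shown here, the exchange of fluoro for chloro on the aromatic carbon ortho to a large group gives the first direct step at this position: an at least 1.2-fold higher number from compound 1 to compound 4 (0.10 log units; that floor lies within the scatter). Compound 4 is recorded only as a limit, > 100000 nM. The true size of the step therefore stays unknown, and the exchange is not shown to change the number beyond the scatter, because the reading stops at a shared ceiling: the limit of > 100000 nM in this assay, at which 2 of the 4 values shown sit.

The compounds shown leave open how a bromo or an amine at this position would read. They also leave open whether the chloro exchange would give a measurable step on a core with a stronger starting value.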